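The compounds below may be only part of what the source reports. "The series", "measured", "known", "first", "only" and "open" are said of these compounds alone.

Compound 1 `COc1ccc(Cl)cc1S(=O)(=O)Nc1ccc(-c2nc3ccccc3o2)cc1`: in an assay on cells for inhibition of HSP60/HSP10 (Homo sapiens), with a stated time of 60 min (a lower number here means a stronger inhibitor, a higher number a weaker inhibitor), compound 1 reaches only the assay limit, > 100000 nM.
Compound 2 `Cc1cccc(S(=O)(=O)Nc2ccc(-c3nc4ccccc4o3)cc2)c1`: in this assay compound 2 likewise reaches only the assay limit, > 100000 nM.

The step that the two limits leave unreadable from compound 1 to compound 2 cannot be read, as both ends sit at the limit (the limit of > 100000 nM in this assay, at which 2 of the 2 values shown sit). For the measured compounds named here, compound 2 thus stands at a limit in this assay, and the one further value shown is a limit as well. Compound 3 `C=Cc1ccc(S(=O)(=O)Nc2ccc(-c3nc4ccccc4o3)cc2)cc1` differs from compound 2 by 4-vinylphenyl in place of 3-methylphenyl on a sulfonyl sulfur. Going by the values given here, no measured step bears directly on this change. Since both values shown sit at the limit (the limit of > 100000 nM in this assay, at which 2 of the 2 values shown sit), no step beyond the scatter is expected, and the step of a number no higher from compound 2 to compound 3 (the limit leaves the size open) is estimated to be small. Compound 3 is estimated at 100000 nM, within 30000 nM to 300000 nM.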

Compound 3, half-maximal inhibitory concentration: > 100000 nM
Compound 3: only a limit was reported (the forecaster's own chance of this, stated with the estimate: 80%); the middle value lies on the limit itself.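

For the compounds shown here, compound 3 also reaches only a limit in this assay, so no step among compound 1, compound 2 and compound 3 can be read: the limit of > 100000 nM in this assay, at which 3 of the 3 values shown sit. The compounds shown leave open whether any group on the sulfonyl sulfur changes the inhibition.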